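Chalcone Hydroxyls Traded for a Methoxy Group

The source may hold more compounds than are shown below. What is called first, only, known or untested is meant among the compounds shown, and "the series" means these compounds.

Measured so far:
compound 1, `COc1cc(OC)c(OC)cc1/C=C/C(=O)c1ccc(O)cc1O`, 37600 nM
compound 2, `COc1cc(OC)c(-c2cc(=O)c3ccc(O)cc3o2)cc1OC`, > 150000 nM

Within the data shown here, in a functional assay on HeLa cells (Homo sapiens) for inhibition, read by MTT assay, with a stated time of 72 h (a higher number here means a weaker inhibitor, a lower number a stronger inhibitor), compound 1 gives 37600 nM, the only numerical value available. Compound 2 reaches only the assay limit of > 150000 nM, so no number is known for it. Among the measured compounds shown here, compound 1 therefore stands alone as the one compound with a measured potency, and it is a weak inhibitor here; the limit of > 150000 nM in this assay, at which 1 of the 2 values shown sits, is the only other observation.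

Compound 3, `COc1ccc(C(=O)/C=C/c2cc(OC)c(OC)cc2OC)cc1`, is not yet measured. It differs from compound 1 by one change, (4-methoxyphenyl in place of 2,4-dihydroxyphenyl on a carbonyl carbon). For the measured compounds named here, no measured pair shows this particular change, so no step from data can be quoted. The expected step from compound 1 to compound 3 in this assay is a 2.5-fold lower number from compound 1 to compound 3 (0.40 log units; beyond the scatter), a modest gain in potency rather than a shift beyond the scatter with certainty. Compound 3 is thus estimated at 15000 nM, with a range from 4000 nM to 60000 nM.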

Compound 3, half-maximal inhibitory concentration: 37600 nM
Compound 3: middle estimate off by 2.5-fold (0.40 log units), on the low side, within the range that was stated.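

In this assay, among these compounds, the exchange of 2,4-dihydroxyphenyl for 4-methoxyphenyl on a carbonyl carbon gives the first step that can be read at this position, and it reads no change at the digits printed from compound 1 to compound 3 (within the scatter). The two hydroxyl groups of compound 1 can therefore be given up, and a single methoxy group put in their place, with no measurable difference in this read-out, so this position tolerates the change at this weak level of inhibition. No measurement shown here bears on why the two compounds read alike.

From the compounds shown here alone, it remains open how the number would respond to an aminophenyl group or a plain phenyl group on the same carbonyl carbon. Going by these compounds, it is also open whether the same exchange would read alike on the core of compound 2.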